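The compounds below may be only part of what the source reports. "The series", "measured", "known", "first", "only" and "open" are said of these compounds alone.

Measured so far:
compound 1 `Cc1cccc(-c2noc(C3CN(S(=O)(=O)c4ccc(Cl)cc4)C3)n2)c1` gives 1100 nM in an assay on HEK293 cells for negative allosteric modulation of metabotropic glutamate receptor 5 (Homo sapiens), read by FLIPR; a higher number here means a weaker inhibitor, a lower number a stronger inhibitor;
compound 2 `O=S(=O)(c1ccc(Cl)cc1)N1CC(c2nc(-c3cccc(Cl)c3)no2)C1` gives 170 nM;
compound 3 `Cc1cccc(-c2noc(C3CN(C(=O)c4ccccc4F)C3)n2)c1` gives 1400 nM.

Compound 2 stands lowest of the three, with compound 1 giving 1100 nM and compound 3 giving 1400 nM. Compound 4 `Cc1cccc(S(=O)(=O)N2CC(c3nc(-c4cccc(Cl)c4)no3)C2)c1` differs from compound 2 in one place: 3-methylphenyl in place of 4-chlorophenyl on a sulfonyl sulfur. Going by the values given here, the only measured step, a 6.5-fold lower number from compound 1 to compound 2 (0.81 log units; beyond the scatter), concerns the other aryl ring, where chloro in place of methyl lowered the number; it bears on compound 4 only loosely, as the change here runs the opposite way, swapping chloro for methyl, and sits on the sulfonyl sulfur. A modest rise is therefore expected, a 2.9-fold higher number from compound 2 to compound 4 (0.47 log units; beyond the scatter). Compound 4 is estimated at 500 nM, with a range of 150 nM to 1700 nM.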

Compound 4, half-maximal inhibitory concentration: 390 nM
Beside the measured number, compound 4's estimate is 1.3-fold (0.11 log units) above it; the measured number falls inside the stated range.
By their numbers in this assay, from the lowest: compound 2; then compound 4; then compounds 1 and 3 (each within the scatter of the next).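

Going by these compounds alone, compounds 1 and 2 both carried 4-chlorophenyl on the sulfonyl sulfur, so this is the first evidence that the number responds to a change there: 3-methylphenyl in place of 4-chlorophenyl gives a 2.3-fold higher number from compound 2 to compound 4 (0.36 log units; beyond the scatter). The substituent and its place on the ring change together, so this step cannot assign the rise to either alone. No measured evidence accounts for the step.

The compounds shown leave open how 4-methylphenyl or unsubstituted phenyl would read on the sulfonyl sulfur, which would separate those two changes. They also leave open whether an amine or a carboxylic acid on that ring would be tolerated.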